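Swapping the Carbonyl Substituent of Compound 1

The source may report more compounds than this note shows. Statements on the series, on what has been measured and on what is new or still open speak of the compounds shown alone.

Compound 1 `COC1CCN(C(=O)N2CC(c3nc(-c4cccc(Cl)c4)no3)C2)CC1` was examined in an assay on HEK293 cells for positive allosteric modulation of metabotropic glutamate receptor 5 (Homo sapiens), read by FLIPR (a higher number here means that more compound is needed for the effect, a lower number that less compound is needed), and gave only a limit of the assay, > 10000 nM. Compound 2 `Cc1cccc(-c2noc(C3CN(S(=O)(=O)c4ccc(F)cc4)C3)n2)c1` likewise gave only a limit in this assay, namely > 10000 nM. For the measured compounds named here, compound 1 therefore stands on no number of its own: the only evidence about it is the limit of > 10000 nM in this assay, at which 2 of the 2 values shown sit, so nothing is known about where either measured compound would fall if the assay reached further.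

Compound 3 `O=C([C@@H]1CC2CCC1C2)N1CC(c2nc(-c3cccc(Cl)c3)no2)C1` has not yet been measured. It differs from compound 1 in one place: a group of 7 heavy atoms (7 carbon; 2 five-membered non-aromatic rings of carbon only) in place of a group of 8 heavy atoms (6 carbon, 1 nitrogen, 1 oxygen; one six-membered non-aromatic ring with 1 hetero atom), on a carbonyl carbon. Going by the values given here, no step between measured compounds is available to guide this change, and the two measured values offer no direction, since both sit at the same limit.

On this thin basis, the step from compound 1 to compound 3 is estimated as an at least 1.6-fold lower number from compound 1 to compound 3 (0.22 log units; that floor lies within the scatter), an expectation that leans only on the chance that leaving the limit is possible. Compound 3 is accordingly expected to give about 6000 nM in this assay, with a range from 600 nM to 40000 nM, and it may well return only a limit again.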

Compound 3, half-maximal effective concentration: 98 nM
Compound 3: the middle estimate sits 61-fold (1.79 log units) above what was measured, and the stated range ends above it.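

In this assay, the group on the carbonyl carbon proves able to decide whether a number can be read at all: exchanging 4-methoxypiperidin-1-yl for the group of two five-membered carbon rings gives an at least 100-fold lower number from compound 1 to compound 3 (2.00 log units; beyond the scatter). For the compounds shown here, compound 3 thereby supplies the only value shown that is a number, and it establishes that this place, on a carbonyl carbon bound to an amide-type nitrogen in a ring, can carry activity on the shared core. The size of the step remains a floor, because its starting point is a limit and not a number: the limit of > 10000 nM in this assay, at which 2 of the 3 values shown sit.

The compounds shown leave open whether the change depends on the carbon-only rings, on the loss of the methoxy group and the ring oxygen-bearing substituent as a whole, or on the defined stereocentre, and a plain piperidin-1-yl or a cyclohexyl group on the same carbonyl carbon would begin to separate these. Also open, from the compounds shown here alone, is whether the mirror-image form of the entering group would give a similar number in this assay.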